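A few compounds are considered here, and "the series" means these few. Any claim that something is new, unique, unknown or untested is made for them only; others in the source may bear on it.

Working notes on the series. The three measured compounds share one core and differ in a single group. Compound 1 `FC(F)(F)c1ccc(CN2CCN(Cc3cc(-c4ccc(OCc5ccccc5)cc4)on3)CC2)cc1` gives 2900 nM in a functional assay on MCF7 cells (Homo sapiens) for antiproliferative activity, read by sulforhodamine B assay, with a stated time of 72 h; a lower number here means a stronger inhibitor, a higher number a weaker inhibitor. Compound 2 `Cc1ccccc1COc1ccc(-c2cc(CN3CCN(Cc4ccc(C(F)(F)F)cc4)CC3)no2)cc1` gives 3700 nM in this assay, and compound 3 `Cc1ccc(COc2ccc(-c3cc(CN4CCN(Cc5ccc(C(F)(F)F)cc5)CC4)no3)cc2)cc1` gives 1200 nM in this assay. Compound 3 holds the lowest number of the three: the step of a 2.4-fold lower number from compound 1 to compound 3 (0.38 log units; beyond the scatter) and the step of a 3.1-fold lower number from compound 2 to compound 3 (0.49 log units; beyond the scatter) are both beyond the scatter, while the step of a 1.3-fold higher number from compound 1 to compound 2 (0.11 log units; within the scatter) is not.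

Compound 4 `COc1ccc(COc2ccc(-c3cc(CN4CCN(Cc5ccc(C(F)(F)F)cc5)CC4)no3)cc2)cc1` is the next member. The change from compound 3 is methoxy in place of methyl on an aromatic carbon. Among the measured compounds shown here, no measured pair covers a methoxy in place of methyl at any position, so the bearing of the existing steps is indirect. The step of a 2.4-fold lower number from compound 1 to compound 3 (0.38 log units; beyond the scatter) shows that a methyl at this aromatic carbon is worth a modest gain over hydrogen, and the step of a 3.1-fold lower number from compound 2 to compound 3 (0.49 log units; beyond the scatter) shows that the placement of that methyl matters to a similar degree; neither says how a methoxy at the same carbon would read. On that basis the step of a 1.3-fold higher number from compound 3 to compound 4 (0.10 log units; within the scatter) is expected to stay within the scatter, with no direction favoured. Compound 4 is therefore estimated at 1500 nM, within a range of 600 nM to 3800 nM.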

Compound 4, half-maximal inhibitory concentration: 1300 nM
Compound 4: the middle estimate sits 1.2-fold (0.06 log units) above what was measured; the range from low to high includes it.
By their numbers in this assay, from the lowest: compounds 3 and 4 (each within the scatter of the next); then compounds 1 and 2 (each within the scatter of the next).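

In this assay, the step of a 1.1-fold higher number from compound 3 to compound 4 (0.03 log units; within the scatter) shows that at this aromatic carbon, para to a large group, methoxy and methyl cannot be told apart, even though methoxy adds an oxygen to the group. The gain over hydrogen seen with methyl is therefore not unique to methyl: the step of a 2.2-fold lower number from compound 1 to compound 4 (0.35 log units; beyond the scatter) is also beyond the scatter, so two different groups at this carbon now separate from the unsubstituted benzyl of compound 1. The step of a 2.8-fold lower number from compound 2 to compound 4 (0.45 log units; beyond the scatter) is likewise beyond the scatter, so the 4-methoxyphenyl group, like the 4-methylphenyl group, stands apart from the 2-methylphenyl group, but no supporting data bear on why these steps read as they do.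

The compounds shown leave open whether the gain holds for groups of other kinds at this carbon, such as a fluorine, a nitrile, a hydroxyl or a carboxylic acid, or for a longer chain such as ethoxy. They also leave open how a methoxy would read at the ring carbon that carries the methyl in compound 2.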